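Nitro for Bromo on a Pair Stuck at the Limit

A few compounds are considered here, and "the series" means these few. Any claim that something is new, unique, unknown or untested is made for them only; others in the source may bear on it.

Compound 1 `CCn1c(/C=C2/C(=O)Nc3ccc(F)cc32)nc2ccccc21` and compound 2 `CCn1c(/C=C2/C(=O)Nc3ccc(Br)cc32)nc2ccccc21` share a core and differ only in the halogen. In a functional assay on A549 cells (Homo sapiens) for cytotoxicity, read by MTT assay, with a stated time of 48 h (on this read-out lower numbers stand for stronger inhibition and higher numbers for weaker inhibition), compound 1 reaches only the limit of > 50000 nM. In this assay compound 2 likewise gives only the limit > 50000 nM. The step that the two limits leave unreadable from compound 1 to compound 2 cannot be read at all, since (the limit of > 50000 nM in this assay, at which 2 of the 2 values shown sit). Compound 3 `CCn1c(/C=C2/C(=O)Nc3ccc([N+](=O)[O-])cc32)nc2ccccc21` carries the change (nitro in place of bromo on an aromatic carbon). Within the data shown here, the one measured step bears on it only insofar as exchanging bromo for fluoro left both compounds outside the measurable range, so it supplies neither a size nor a direction. With no readable step to lean on, compound 3 is expected to remain at or near the same limit, with no shift beyond the scatter. The expected step in this assay is a step that the limit leaves unreadable from compound 2 to compound 3. Compound 3 is therefore estimated at 60000 nM, in a range from 10000 nM to 300000 nM.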

Compound 3, half-maximal inhibitory concentration: > 50000 nM
Compound 3 gave a limit, no number; the forecaster's own chance of this, stated with the estimate: 70%; the middle value is on the limit's open side.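

Compound 1, compound 2 and compound 3 all stop at a limit in this assay, so no step among them can be read: the limit of > 50000 nM in this assay, at which 3 of the 3 values shown sit.

The compounds shown leave open whether fluoro, bromo and nitro differ at all in this read-out, and what any of the three would give as an actual number.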